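Cytotoxicity notes: benzyl replacing benzylcarbamoyl on the ring amine

This account rests on a few compounds, and the source may have more. Where it says the series, first, only, none or still open, it means among the compounds named here.

The series shares one core. Compound 1 `Cc1nc2c(c(-c3cc(F)c4c(c3C)CCCO4)c1[C@H](OC(C)(C)C)C(=O)O)CN(CC1CC1c1ccccc1)CC2`, compound 2 `Cc1ccc(CCCN2CCc3nc(C)c([C@H](OC(C)(C)C)C(=O)O)c(-c4cc(F)c5c(c4C)CCCO5)c3C2)cc1F` and compound 3 `Cc1ccc(-c2c3c(nc(C)c2[C@H](OC(C)(C)C)C(=O)O)CCN(C(=O)NCc2ccccc2)C3)cc1` have been tested in an ADME assay on MT2 cells (Homo sapiens) for cytotoxicity, read by XTT assay, with a stated time of 4 days (on this read-out higher numbers stand for lower toxicity in this test and lower numbers for higher toxicity in this test), while compound 4 `Cc1ccc(-c2c3c(nc(C)c2[C@H](OC(C)(C)C)C(=O)O)CCN(Cc2ccccc2)C3)cc1` still awaits measurement.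

In this assay compound 1 reaches only the limit of the assay, > 40000 nM. In this assay compound 2 likewise gives only a limit, > 40000 nM. In this assay compound 3 again returns a limit rather than a number, > 40000 nM. Among the compounds with values here, the single step between compounds that differ in one place, a step that the two limits leave unreadable from compound 1 to compound 2, therefore has no readable size, since both of its ends are limits. Compound 3 thus stands where the whole series stands so far: at the limit, (the limit of > 40000 nM in this assay, at which 3 of the 3 values shown sit).

The change to compound 4 is benzyl in place of benzylcarbamoyl on an amine nitrogen in a ring. Within the data shown here, no measured step bears directly on this position, and the one step available is unreadable, so there is no basis for expecting a shift beyond the scatter. Given that every value so far sits at the limit (the limit of > 40000 nM in this assay, at which 3 of the 3 values shown sit), compound 4 is expected to sit there as well, an estimated step of a number no higher from compound 3 to compound 4 (the limit leaves the size open). Compound 4 is estimated at 40000 nM, expected to lie between 20000 nM and 80000 nM, most likely reported again only as a limit.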

Compound 4, half-maximal cytotoxic concentration: > 40000 nM
Compound 4 gave a limit, no number; the forecaster's own chance of this, stated with the estimate: 85%; the middle value sits exactly at the limit.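

In this assay compound 4 gives > 40000 nM as a limit and not a number, and with compound 3 also at a limit, the step between the two cannot be read. The compounds shown leave open whether benzyl and benzylcarbamoyl differ on an amine nitrogen in a ring, and at what concentration any compound becomes toxic in this test: the limit of > 40000 nM in this assay, at which 4 of the 4 values shown sit.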